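The source may hold more compounds than are shown below. What is called first, only, known or untested is meant among the compounds shown, and "the series" means these compounds.

Compound 1, `OCCNc1nnc2nncn2n1`, measured in a functional assay on BeWo cells (Homo sapiens) for inhibition, read by MTT assay, with a stated time of 72 h; on this read-out higher numbers stand for weaker inhibition and lower numbers for stronger inhibition: compound 1 gives 3310 nM.
Compound 2, `c1nnc2nnc(N3CCCC3)nn12`: compound 2 gives 4290 nM.
Compound 3, `CCCCC(=O)N1CCN(c2nnc3nncn3n2)CC1`: compound 3 gives 1720 nM.

Compound 3 has the lowest of the three numbers. Its gap to compound 1 lies within the scatter, so the two cannot be ordered against each other; its gap to compound 2 lies beyond the scatter. Compound 4, `CC(C)(C)C(=O)N1CCN(c2nnc3nncn3n2)CC1`, differs from compound 3 in one place: tert-butyl in place of butyl on a carbonyl carbon. Within the data shown here, no step between measured compounds bears on this change, so the expectation rests on compound 3 alone, whose value 1720 nM sets the starting point. In this assay the step expected is a 1.2-fold higher number from compound 3 to compound 4 (0.07 log units; within the scatter), that is, none beyond the scatter. Compound 4 is estimated at 2000 nM, with a range from 800 nM to 5000 nM.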

Compound 4, half-maximal inhibitory concentration: 2410 nM
The estimate for compound 4 lay 1.2-fold (0.08 log units) below the measured number; the range from low to high includes it.
By their numbers in this assay, from the lowest: compounds 3, 4, 1 and 2 (each within the scatter of the next, the first and the last beyond it).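

In this assay, tert-butyl in place of butyl on the carbonyl carbon gives a 1.4-fold higher number from compound 3 to compound 4 (0.15 log units; within the scatter) and so leaves the two compounds unresolved. Among these compounds, this is the first comparison at this position, and it shows that this change of chain shape on the carbonyl carbon produces no difference that can be read beyond the scatter. Nothing at hand offers an explanation for this result. The compounds shown leave open whether a longer chain, a cyclohexyl ring or an amine on this carbonyl carbon would move the number beyond the scatter.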